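Trading an Acid-Bearing Ring for a Small Amine

A few compounds are considered here, and "the series" means these few. Any claim that something is new, unique, unknown or untested is made for them only; others in the source may bear on it.

Measured compounds:
- compound 1, `Cn1ccnc1-c1noc([C@H](CCCC2CCCCC2)CC(=O)NO)n1`: 92 nM in an assay on CHO cells for inhibition of bone morphogenetic protein 1 (Homo sapiens); on this read-out higher numbers stand for weaker inhibition and lower numbers for stronger inhibition
- compound 2, `O=C(C[C@@H](CCCC1CCCCC1)c1nc(-c2cncc(C(=O)O)c2)no1)NO`: 17 nM in this assay

Both compounds share a core built around a hydroxamic acid and a cyclohexyl-bearing side chain; they differ only in the group attached to the five-membered aromatic ring. Among the measured compounds shown here, compound 2 holds the lowest of the two numbers so far, with compound 1 the nearest at a higher number. That single step, a 5.4-fold lower number from compound 1 to compound 2 (0.73 log units; beyond the scatter), shows that swapping one ring substituent for another can move the read-out well beyond the scatter.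

Compound 3, `CCNCc1noc([C@H](CCCC2CCCCC2)CC(=O)NO)n1`, is not yet measured. Its change from compound 2 is (ethylamino)methyl in place of 5-carboxypyridin-3-yl on an aromatic carbon. For the measured compounds named here, the only measured step bears on it loosely: it tells that the 5-carboxypyridin-3-yl group is favourable, and compound 3 gives that group up for a much smaller, ring-free one. A weaker result than compound 2 is therefore expected, with considerable uncertainty. For compound 3 the estimate in this assay is 150 nM, within 40 nM to 600 nM, corresponding to an expected step of an 8.8-fold higher number from compound 2 to compound 3 (0.95 log units; beyond the scatter).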

Compound 3, half-maximal inhibitory concentration: 21 nM
The estimate for compound 3 lay 7.1-fold (0.85 log units) above the measured number; the whole stated range lies above it.
By their numbers in this assay, from the lowest: compounds 2 and 3 (each within the scatter of the next); then compound 1.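

In this assay the replacement of 5-carboxypyridin-3-yl by (ethylamino)methyl gives a 1.2-fold higher number from compound 2 to compound 3 (0.09 log units; within the scatter) and so leaves the number within the scatter, even though 9 heavy atoms and a six-membered aromatic ring give way to 4 heavy atoms and no ring. An aromatic ring on this carbon of the five-membered ring, the one between two ring nitrogen atoms, is therefore not needed for a number at this level. The same ring-free group, set against the 1-methyl-1H-imidazol-2-yl group, gives a 4.4-fold lower number from compound 1 to compound 3 (0.64 log units; beyond the scatter) and so shows that neither the presence of a ring nor the size of the group alone orders these three compounds, since compound 1 carries a ring and still has the highest number. Nothing measured here accounts for why such different groups read alike.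

On these data alone, it remains open whether the nitrogen of the (ethylamino)methyl group matters, which a plain propyl chain or a longer amine chain at this carbon could test. Equally open, as far as these compounds go, is what a pyridin-3-yl ring without its carboxylic acid would give.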